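Chloro for hydrogen on the cinnamate ring

The source may hold more compounds than are shown below. What is called first, only, known or untested is meant among the compounds shown, and "the series" means these compounds.

Compound 1 `CCOC(=O)/C=C/c1cc(OC)ccc1OC(=O)c1nc(C)c(C)nc1C`, compound 2 `Cc1nc(C)c(C(=O)Oc2ccc(Cl)cc2/C=C/C(=O)O)nc1C` and compound 3 `CCOC(=O)/C=C/c1ccccc1OC(=O)c1nc(C)c(C)nc1C` were examined in a functional assay on EA.hy 926 cells (Homo sapiens) for cytotoxicity, read by MTT assay, with stated times of 24 h and 12 h, tested at 12.5 uM; on this read-out higher numbers stand for a stronger effect at the one concentration tested and lower numbers for a weaker effect. In this assay compound 1 gives 15.9%, compound 2 gives 6.9% and compound 3 gives 9.6%. Among the measured compounds shown here, compound 3 sits in the middle of the three numbers, and its gaps to compound 1 and to compound 2 both fall within the scatter; the only single change among the measured compounds, a number 6.3 percentage points lower from compound 1 to compound 3 (within the scatter), is likewise within the scatter.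

Compound 4 `CCOC(=O)/C=C/c1cc(Cl)ccc1OC(=O)c1nc(C)c(C)nc1C` differs from compound 3 by chloro in place of hydrogen on an aromatic carbon. For the measured compounds named here, no measured step shows a chloro entering at this place; the step from compound 1 to compound 3 is the only one at this aromatic carbon, and it lies within the scatter. Compound 2 also carries a chloro, but it differs from compound 3 in more than one place, so its value can only be noted. Compound 4 is therefore expected to show a number 1.4 percentage points higher from compound 3 to compound 4 (within the scatter), a step not beyond the scatter. In this assay compound 4 is estimated at 11%, within a range from 3% to 22%.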

Compound 4, a percentage reported as activity, at one concentration (the size of the read-out at that concentration, not a potency): 64.9%
Compound 4: middle estimate off by 53.9 percentage points, on the low side, outside the stated range (above it).
By their numbers in this assay, from the lowest: compounds 2, 3 and 1 (each within the scatter of the next); then compound 4.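

In this assay, among the compounds shown here, the aromatic carbon para to a large group is far from indifferent: chloro in place of hydrogen gives a number 55.3 percentage points higher from compound 3 to compound 4 (beyond the scatter), whereas the only earlier step at this carbon, a number 6.3 percentage points lower from compound 1 to compound 3 (within the scatter), stayed within the scatter. Chloro in place of methoxy at the same carbon gives a number 49 percentage points higher from compound 1 to compound 4 (beyond the scatter), and ethyl in place of the acid hydrogen gives a number 58 percentage points higher from compound 2 to compound 4 (beyond the scatter), so among these compounds the high number appears only where chloro and the ethyl ester occur together. No measurement given here bears on why this happens.

On these data alone, it remains open whether bromo, fluoro or an amine at this carbon would give a similar number, and whether a longer chain in place of the ethyl would keep it. As far as these compounds go, with a single concentration tested, compound 4 is known only to give a stronger effect at that concentration; how its effect would change at other concentrations remains open.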